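The source may hold more compounds than are shown below. What is called first, only, known or untested is meant among the compounds shown, and "the series" means these compounds.

Measured in a functional assay on HeLa cells (Homo sapiens) for inhibition, read by sulforhodamine B assay; a higher number here means a weaker inhibitor, a lower number a stronger inhibitor:
- compound 1 `O=C1C=C(N2CCC2)C(=O)c2c1nc1n2[C@H]2OC[C@@H](O)[C@H]2OC1`: > 16000 nM
- compound 2 `CCc1ccc(NC2=CC(=O)c3c(nc4n3[C@H]3OC[C@@H](O)[C@H]3OC4)C2=O)cc1`: 6510 nM

Compound 1 stands at a limit of this assay, > 16000 nM, which is not an exact number. Compound 3 `CCc1ccc(NC2=CC(=O)c3nc4n(c3C2=O)[C@H]2OC[C@@H](O)[C@H]2OC4)cc1` replaces the azetidin-1-yl of compound 1 with (4-ethylphenyl)amino on a double-bonded ring carbon: (4-ethylphenyl)amino in place of azetidin-1-yl on a double-bonded ring carbon. Compound 2, which also carries (4-ethylphenyl)amino, gives 6510 nM, and this value anchors the expectation. The expected change, an at least 2.6-fold lower number from compound 1 to compound 3 (0.42 log units; beyond the scatter), is towards stronger inhibition, although its size is uncertain as the starting point is only a limit. The estimate for compound 3 is 6000 nM, with an expected range of 2000 nM to 16000 nM.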

Compound 3, half-maximal inhibitory concentration: 3990 nM
Compound 3: the middle estimate sits 1.5-fold (0.18 log units) above what was measured; low and high end bracket the measured number.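

In this assay, (4-ethylphenyl)amino in place of azetidin-1-yl on this double-bonded ring carbon gives an at least 4.0-fold lower number from compound 1 to compound 3 (0.60 log units; beyond the scatter). The position therefore responds to the group it carries, and this change moves the number towards stronger inhibition. Compound 1 gives > 16000 nM, which is a limit and not an exact number, so the full size of the step stays unknown: the limit of > 16000 nM in this assay, at which 1 of the 3 values shown sits.

From the compounds shown here alone, the step swaps the ring, the ethyl group and the hydrogen on the nitrogen all at once, so which of these matters remains open. Plain phenylamino, without the ethyl, or an open-chain amine such as diethylamino could begin to separate them.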